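A few compounds are considered here, and "the series" means these few. Any claim that something is new, unique, unknown or untested is made for them only; others in the source may bear on it.

Measured compounds:
Compound 1, `COc1ncc(C(F)(F)F)cc1CO[C@H]1[C@H](C(C)(C)C)[C@@H](C(=O)O)N(C(=O)C2CCCCC2)[C@H]1c1ccccc1`: 150 nM
Compound 2, `COc1ncc(C(C)(C)C)cc1CO[C@H]1[C@H](C(C)(C)C)[C@@H](C(=O)O)N(C(=O)C2CCCCC2)[C@H]1c1ccccc1`: 132 nM

Among the measured compounds shown here, in an assay on cells with Cystic fibrosis transmembrane conductance regulator variant F508del (Homo sapiens) as the target, read by voltage clamp, with a stated time of 24 h, in the presence of a further agent that is not named here (on this read-out higher numbers stand for an effect only at larger amounts of compound and lower numbers for an effect already at smaller amounts), compound 1 gives 150 nM and stands as the higher of the two numbers, with its only neighbour, compound 2, at 132 nM; the step of a 1.1-fold lower number from compound 1 to compound 2 (0.06 log units; within the scatter) is within the scatter, so the two compounds cannot be ordered. Compound 3, `COc1ncc(C(F)(F)F)cc1CO[C@H]1[C@H](C(C)(C)C)[C@@H](C(=O)O)N(C(=O)OC(C)C)[C@H]1c1ccccc1`, has not yet been measured in this assay. It departs from compound 1 in one place: isopropoxy in place of cyclohexyl on a carbonyl carbon. For the measured compounds named here, the single measured step, a 1.1-fold lower number from compound 1 to compound 2 (0.06 log units; within the scatter), concerns a substituent on the aromatic ring and says nothing about the group on the carbonyl carbon, so no measured step bears on the change to compound 3. Without such guidance, the replacement of cyclohexyl by isopropoxy is expected to cost some activity, though not far beyond the scatter, so the estimated step is a 2.0-fold higher number from compound 1 to compound 3 (0.30 log units; within the scatter). For compound 3 the expected value in this assay is therefore estimated at 300 nM, with a range from 100 nM to 1000 nM.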

Compound 3, half-maximal effective concentration: 137 nM
The estimate for compound 3 lay 2.2-fold (0.34 log units) above the measured number; measured number inside the range.
By their numbers in this assay, from the lowest: compounds 2, 3 and 1 (each within the scatter of the next).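

In this assay the exchange of cyclohexyl for isopropoxy on the carbonyl carbon gives a 1.1-fold lower number from compound 1 to compound 3 (0.04 log units; within the scatter) and so leaves the two compounds unordered. Among the compounds shown here, this is the first reading at this position, since the earlier pair spoke only to a substituent on the aromatic carbon, and it shows that the carbonyl carbon on the amide-type nitrogen in a ring can lose the six-membered carbon ring and take on an oxygen, going from cyclohexylcarbonyl to isopropoxycarbonyl, with no change beyond the scatter. The data on hand offer no independent measurement that would account for this result.

What the compounds shown leave open is whether this position stays as undemanding with groups of other kinds on the carbonyl carbon, such as an amine like dimethylamino, a longer chain like n-hexyl, or an aromatic phenyl ring. They also leave open whether isopropoxy on the carbonyl carbon and tert-butyl on the aromatic carbon, each read so far only on its own against compound 1, would hold together in a single compound.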